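A few compounds are considered here, and "the series" means these few. Any claim that something is new, unique, unknown or untested is made for them only; others in the source may bear on it.

Compound 1 `COc1cc(C2=NN(C(C)=O)C(c3cc(Cl)cc(Cl)c3)O2)cc(OC)c1OC` carries a 3,5-dichlorophenyl group on a saturated ring carbon of its five-membered core. In a functional assay on PC-3 cells (Homo sapiens) for antiproliferative activity, read by MTT assay, tested at 5 uM (on this read-out higher numbers stand for a stronger effect at the one concentration tested and lower numbers for a weaker effect), compound 1 gives 93.9%, the higher of the two values measured here. Compound 2 `COc1cc(C(=O)N/N=C/c2ccccc2F)cc(OC)c1OC`, built on a different core, gives 81.8% in this assay, and the gap between compound 1 and compound 2 lies beyond the usual scatter of this kind of measurement, so compound 1 is the stronger of the two.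

Compound 3 `COc1cc(C2=NN(C(C)=O)C(c3ccc(C(F)(F)F)cc3)O2)cc(OC)c1OC` has not yet been measured. It differs from compound 1 in one place: 4-(trifluoromethyl)phenyl in place of 3,5-dichlorophenyl on a saturated ring carbon. For the measured compounds named here, no measured pair of compounds shows what such a swap does, so the size of the step can only be expected, not read off. The step from compound 1 to compound 3 is expected to be modest, a number 8.9 percentage points lower from compound 1 to compound 3 (within the scatter), a slight drop that may well stay within the scatter. Compound 3 is therefore expected to give about 85% in this assay, most likely between 65% and 97%.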

Compound 3, a percentage reported as inhibition, at one concentration (the size of the read-out at that concentration, not a potency): -0.7%
The estimate for compound 3 lay 85.7 percentage points above the measured number, and the stated range ends above it.
By their numbers in this assay, from the lowest: compound 3; then compound 2; then compound 1.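

On the saturated ring carbon of the shared core, the choice of aromatic group can make the difference between a strong and an absent effect in this assay: with the rest of the molecule unchanged, putting 4-(trifluoromethyl)phenyl in place of 3,5-dichlorophenyl gives a number 94.6 percentage points lower from compound 1 to compound 3 (beyond the scatter). The earlier comparison could not show this, as its two compounds have different cores and so say nothing about any single position. Both groups here are built on a six-membered aromatic ring of carbon only, so having such a ring at this position does not by itself keep the effect.

No measurement at hand explains why the two groups part so sharply. Also open, on these data alone, is what a plain phenyl or a 4-chlorophenyl group on this carbon would give, which could show whether the chlorine atoms support the effect or the trifluoromethyl group removes it.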